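A few compounds are considered here, and "the series" means these few. Any claim that something is new, unique, unknown or untested is made for them only; others in the source may bear on it.

Going by the values given here, in a functional assay on SK-BR-3 cells (Homo sapiens) for antiproliferative activity, read by MTT assay, with a stated time of 72 h (a lower number here means a stronger inhibitor, a higher number a weaker inhibitor), only two compounds have numbers so far. Compound 1 (`CC(Nc1ncnc2ccc(-c3cnn(C4CCNCC4)c3)cc12)c1c(Cl)ccc(F)c1Cl`) gives 4390 nM and holds the lower of the two. Compound 2 (`COc1cccc(CNc2ncnc3ccc(-c4cnn(C)c4)cc23)c1`) gives 36000 nM and so stands higher, by a gap beyond the usual scatter of repeated measurements. These two differ in more than one place, so their gap cannot be tied to any single structural change.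

Compound 3 (`CC(Nc1nc(N)nc2ccc(-c3cnn(C4CCNCC4)c3)cc12)c1c(Cl)ccc(F)c1Cl`) departs from compound 1 in one place only: amino in place of hydrogen on an aromatic carbon. This is amino in place of hydrogen on an aromatic carbon, between two ring nitrogen atoms. Among the compounds with values here, no measured pair shows what this change does in this assay, so the expectation rests on compound 1 at 4390 nM as its only direct anchor and must stay broad. The expected result is a small move toward stronger inhibition, not clearly beyond the scatter, and the estimated step is a 1.8-fold lower number from compound 1 to compound 3 (0.24 log units; within the scatter) in all. For compound 3 the estimated value is 2500 nM with an expected range from 700 nM to 9000 nM when it is measured.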

Compound 3, half-maximal inhibitory concentration: 1580 nM
Compound 3: the middle estimate sits 1.6-fold (0.20 log units) above what was measured, and the stated range covers the measured number.
By their numbers in this assay, from the lowest: compound 3; then compound 1; then compound 2.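

In this assay, the aromatic carbon between two ring nitrogen atoms now has its first direct reading: amino in place of hydrogen gives a 2.8-fold lower number from compound 1 to compound 3 (0.44 log units; beyond the scatter), a modest move toward stronger inhibition that lies beyond the scatter. With the rest of compound 1 unchanged, this shows that the position accepts the amino group and that the step can be tied to this single change, which the gap between compound 1 and compound 2 could not do. No accompanying measurement bears on what lies behind the step.

The compounds shown leave open whether this gain is specific to amino or would also appear with a methyl group, a hydroxyl group or a methylamino group on the same carbon. They also leave open whether the same change would give a similar step on compound 2, which differs from compound 1 in more than one place, as this single pair cannot show whether the effect extends beyond the groups carried by compound 1.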